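Compound 4: Exchanging One Aromatic Group of Compound 3

This account rests on a few compounds, and the source may have more. Where it says the series, first, only, none or still open, it means among the compounds named here.

Of the compounds shown here, three with a shared core have been measured in an ADME assay on microsomes from liver (Rattus norvegicus) for metabolic stability, read by LC-MS, using NADPH, with a stated time of 10 min, tested at 0.1 uM; on this read-out higher numbers stand for fast clearance and lower numbers for slow clearance. Compound 1 (`COc1ccc(F)cc1N1C(=O)CSC1c1cccc(C(=O)NCCCCn2cccn2)c1`) gives 1470 mL.min-1.g-1, compound 2 (`COc1ccccc1N1C(=O)CSC1c1cc(F)cc(C(=O)NCCCCc2ccccc2)c1`) gives 3260 mL.min-1.g-1, and compound 3 (`COc1ccc(F)cc1N1C(=O)CSC1c1cccc(C(=O)NCCCCc2ccccc2)c1`) gives 2300 mL.min-1.g-1. Compound 3 lies within the usual scatter of each of the other two.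

Compound 4 (`Cc1cccc(N2C(=O)CSC2c2cccc(C(=O)NCCCCc3ccccc3)c2)c1`) has not yet been measured. It carries 3-methylphenyl in place of 5-fluoro-2-methoxyphenyl on an amide-type nitrogen in a ring.

Among the measured compounds shown here, no measured step changes the group at that place. For the measured compounds named here, the only single-place step is a 1.6-fold higher number from compound 1 to compound 3 (0.19 log units; within the scatter), which lies within the scatter and concerns phenyl in place of 1H-pyrazol-1-yl on a saturated chain carbon. It therefore bears only indirectly on this exchange. Going by the values given here, compound 2 differs from compound 3 in more than one place, so that pair offers no clean step. The data give neither a size nor a direction for the new exchange, which leaves compound 3, at 2300 mL.min-1.g-1, as the best starting point. The expected change is a 1.1-fold higher number from compound 3 to compound 4 (0.04 log units; within the scatter), an estimate that stays within the scatter. In this assay, the estimated value for compound 4 is 2500 mL.min-1.g-1, with an expected range from 1200 mL.min-1.g-1 to 5000 mL.min-1.g-1.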

Compound 4, intrinsic clearance in microsomes: 3140 mL.min-1.g-1
For compound 4 the middle estimate is 1.3-fold (0.10 log units) below the measured one; measured number inside the range.
By their numbers in this assay, from the lowest: compounds 1, 3, 4 and 2 (each within the scatter of the next, the first and the last beyond it).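

In this assay, among the compounds shown here, this is the first step at the group on the amide-type nitrogen in a ring, and it amounts to a 1.4-fold higher number from compound 3 to compound 4 (0.14 log units; within the scatter), which lies within the usual scatter of repeated measurements. For the compounds shown here, the exchange is not a small one on paper: the methoxy group and the fluorine leave, a methyl group enters, and the one hydrogen-bond acceptor counted in the leaving group has no counterpart in the entering one, yet this read-out does not separate the two groups. Nothing available here bears on why the two groups read alike.

At this place the compounds shown carry only substituted phenyl rings, so it stays open whether a pyridine ring, a saturated cyclohexyl ring or a phenyl ring bearing an amine would also stay within the scatter of compound 3. From the compounds shown here alone, it is also open whether the same exchange would read alike in a compound whose chain ends in 1H-pyrazol-1-yl rather than phenyl, since this step was read with the phenyl chain end alone.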